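This account rests on a few compounds, and the source may have more. Where it says the series, first, only, none or still open, it means among the compounds named here.

Compound 1 `CC(c1ccc(-c2ccccc2)c(F)c1)c1nnc2n1N=C(c1ccc(C(F)(F)F)cc1)CS2` and compound 3 `Cc1ccc(C2=Nn3c(nnc3C(C)c3ccc(-c4ccccc4)c(F)c3)SC2)cc1` share one core and differ in a single place: methyl in place of trifluoromethyl on an aromatic carbon. In a functional assay on HCT-116 cells (Homo sapiens) for inhibition, read by sulforhodamine B assay, with a stated time of 72 h (on this read-out lower numbers stand for stronger inhibition and higher numbers for weaker inhibition), compound 1 gives 6100 nM, and compound 3 gives 4800 nM; the change therefore made a 1.3-fold lower number from compound 1 to compound 3 (0.10 log units; within the scatter). Compound 2 `COc1ccc2cc(C(C)c3nnc4n3N=C(c3ccc(C(F)(F)F)cc3)CS4)ccc2c1` carries the same trifluoromethyl group on another core; the difference between the two cores is not broken down here. In this assay compound 2 gives 10800 nM. Compound 4 `COc1ccc2cc(C(C)c3nnc4n3N=C(c3ccc(C)cc3)CS4)ccc2c1` has not yet been measured. It stands to compound 2 exactly as compound 3 stands to compound 1, the same change in the same place: methyl in place of trifluoromethyl on an aromatic carbon. Because that earlier change gave a 1.3-fold lower number from compound 1 to compound 3 (0.10 log units; within the scatter), a similarly small step is expected here too, namely a 1.3-fold lower number from compound 2 to compound 4 (0.11 log units; within the scatter). This rests on a single earlier example, so it is only a loose guide. On that basis compound 4 is estimated at 8300 nM, with a likely range from 4000 nM to 17000 nM.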

Compound 4, half-maximal inhibitory concentration: 10200 nM
Compound 4: the middle estimate sits 1.2-fold (0.09 log units) below what was measured; low and high end bracket the measured number.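

In this assay, the swap from 4-(trifluoromethyl)phenyl to 4-methylphenyl on the second core gives a 1.1-fold lower number from compound 2 to compound 4 (0.02 log units; within the scatter). Set beside the earlier case, the change behaves alike on both cores, and the two steps cannot be told apart: the same change on two cores in this assay, a 1.3-fold lower number (0.10 log units; within the scatter) from compound 1 to compound 3 and a 1.1-fold lower number (0.02 log units; within the scatter) from compound 2 to compound 4, 1.2-fold (0.08 log units) apart, within the scatter of two such steps. Going by these compounds alone, this shows only that the swap leaves no readable mark on the number on either of these two cores, so it does not show that the swap has a real effect of any size, nor that the same would hold on a third core or in a different assay.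

The compounds shown carry only methyl or trifluoromethyl at this place on the ring, so it remains open whether a quite different group there, such as an amine or a carboxylic acid, would shift the number beyond the scatter. On these data alone, whether any such group would behave in the same way on both cores is also open.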